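The compounds below may be only part of what the source reports. "The series", "measured", "known", "first", "only" and "open" are said of these compounds alone.

Measured so far:
compound 1 `Nc1scc(CN2CCN(c3ccc(F)c(F)c3)CC2)c1C(=O)c1ccc(Cl)cc1` — 0%
compound 2 `Nc1scc(CN2CCN(c3cccc(F)c3F)CC2)c1C(=O)c1ccc(Cl)cc1` — 0%

In an assay on CHO cells for displacement of a labelled ligand from adenosine receptor A1 (Homo sapiens), read by scintillation counting, with a stated time of 120 min, tested at 10 uM (a higher number here means more inhibition at the concentration tested (going by the name of the read-out), a lower number less inhibition), compound 1 gives 0% and compound 2 gives 0%. Going by the values given here, the one measured step, no change at the digits printed from compound 1 to compound 2 (within the scatter), changed nothing beyond the scatter, so compound 2 stands level with compound 1 at the digits printed; neither shows displacement at the concentration tested.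

Compound 3 `Nc1scc(CN2CCN(c3c(F)cc(F)cc3F)CC2)c1C(=O)c1ccc(Cl)cc1` is the next member, obtained from compound 2 by the change (2,4,6-trifluorophenyl in place of 2,3-difluorophenyl on an amine nitrogen in a ring). Among the compounds with values here, the only step that bears on it is the one from compound 1 to compound 2, a swap of one fluorinated phenyl on the same ring nitrogen for another, which was flat. Within the data shown here, with both measured members at the floor of this assay and no aryl variation so far having moved the read-out, the expected step of no change at the digits printed from compound 2 to compound 3 (within the scatter) is none beyond the scatter. Compound 3 is therefore estimated at 0%, within 0% to 10%.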

Compound 3, a percentage reported as inhibition, at one concentration (the size of the read-out at that concentration, not a potency): 0%
Estimate against measurement, compound 3: no gap at the digits printed; low and high end bracket the measured number.
By their numbers in this assay, from the lowest: compounds 1, 2 and 3 (each within the scatter of the next).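

In this assay, the change to 2,4,6-trifluorophenyl on the amine nitrogen in the ring gives no change at the digits printed from compound 2 to compound 3 (within the scatter), and the comparison with the 3,4-difluorophenyl member gives no change at the digits printed from compound 1 to compound 3 (within the scatter). This position has now carried three fluorine patterns, including a third fluorine, and the extra fluorine does not separate compound 3 from the two difluorophenyl members in this read-out. No supporting data bear on why the read-out stays flat.

With all three compounds at the same value, these results cannot show whether this position can influence the read-out at all, since the aryl groups compared are all fluorophenyl. On these data alone, a methoxy group or a chlorine on the phenyl, or a pyridine in its place, remains open, as does replacing the chlorine on the other aryl group with an amine.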